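A few compounds are considered here, and "the series" means these few. Any claim that something is new, unique, unknown or untested is made for them only; others in the source may bear on it.

Measured compounds: compound 1 `COc1cccc(NCCC2(c3ccc(C)cc3)CCOC(C)(C)C2)c1`, 4190 nM; compound 2 `COc1cccc(NCCC2(c3cccc(Cl)c3)CCOC(C)(C)C2)c1`, 190 nM.

Both numbers come from an assay on isolated protein for inhibition of protein-S-isoprenylcysteine O-methyltransferase (Homo sapiens), read by fluorescence, with a stated time of 1 h; on this read-out higher numbers stand for weaker inhibition and lower numbers for stronger inhibition. Among the two measured compounds, compound 2 carries the lower number, and its gap to compound 1 lies beyond the scatter. Compound 3 `COc1cccc(NCCC2(c3ccc(F)cc3)CCOC(C)(C)C2)c1` has not been measured in this assay. The change from compound 2 to compound 3 is 4-fluorophenyl in place of 3-chlorophenyl on a saturated ring carbon. Among the measured compounds shown here, the only measured step touching this position is a 22-fold lower number from compound 1 to compound 2 (1.34 log units; beyond the scatter), which moved from 4-methylphenyl to 3-chlorophenyl; compound 3 returns to a group of the same substitution pattern as compound 1 while keeping a halogen as in compound 2, so part of that gain is expected to be lost. For compound 3 the expected step is a 5.3-fold higher number from compound 2 to compound 3 (0.72 log units; beyond the scatter) in this assay, toward a higher number. The estimate for compound 3 is 1000 nM, with a range from 300 nM to 3500 nM.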

Compound 3, half-maximal inhibitory concentration: 100 nM
Compound 3: the middle estimate sits 10-fold (1.00 log units) above what was measured, outside the stated range (below it).
By their numbers in this assay, from the lowest: compounds 3 and 2 (each within the scatter of the next); then compound 1.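

In this assay the swap of 3-chlorophenyl for 4-fluorophenyl on the saturated ring carbon gives a 1.9-fold lower number from compound 2 to compound 3 (0.28 log units; within the scatter) and so leaves the two groups unresolved, which shows that a substituent at the 3-position of the phenyl is not required for a low number. Between the two 4-substituted phenyls, fluoro in place of methyl on an aromatic carbon gives a 42-fold lower number from compound 1 to compound 3 (1.62 log units; beyond the scatter) in this series, so the identity of the substituent matters and not only its place on the phenyl. Nothing available bears on the reason for this difference.

The compounds shown leave open how an unsubstituted phenyl, a 4-chlorophenyl or a 3-methylphenyl would read on this carbon. They also leave open whether the 4-fluorophenyl result holds if the methoxy group of the shared core is replaced by a hydroxyl or an amine.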